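The source may report more compounds than this note shows. Statements on the series, on what has been measured and on what is new or still open speak of the compounds shown alone.

Of the compounds shown here, two have been measured so far. Among the measured compounds shown here, compound 1 `COc1cc(/C=C/C(C)=O)ccc1OCc1cn(-c2ccccc2OC)nn1` is the one with the lower number: in a functional assay on PC-3 cells (Homo sapiens) for antiproliferative activity, read by MTT assay, with a stated time of 48 h (on this read-out higher numbers stand for weaker inhibition and lower numbers for stronger inhibition), compound 1 gives 2050 nM. Compound 2 `COc1cc(/C=C/C(C)=O)ccc1OCc1cn(-c2ccc(C(F)(F)F)c(C(F)(F)F)c2)nn1` carries two trifluoromethyl groups in place of the methoxy, and in this assay compound 2 gives 67200 nM, a far higher number than compound 1, so the two sit well apart. Compound 3 `COc1cc(/C=C/C(C)=O)ccc1OCc1cn(-c2ccccc2)nn1` has not yet been measured. It differs from compound 1 in one place: hydrogen in place of methoxy on an aromatic carbon, on an aromatic carbon of a six-membered aromatic ring of carbon only. For the measured compounds named here, no step between measured compounds matches this change, so the expectation rests on the change itself and remains loose: a step of a 1.7-fold higher number from compound 1 to compound 3 (0.23 log units; within the scatter) is expected, most likely toward a somewhat higher number, though it may stay within the scatter. In this assay compound 3 is estimated at 3500 nM, with a likely range from 1200 nM to 12000 nM.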

Compound 3, half-maximal inhibitory concentration: 78600 nM
For compound 3 the middle estimate is 22-fold (1.35 log units) below the measured one, outside the stated range (above it).
By their numbers in this assay, from the lowest: compound 1; then compounds 2 and 3 (each within the scatter of the next).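

In this assay, the change from 2-methoxyphenyl to phenyl is far from a minor edit: hydrogen in place of methoxy gives a 38-fold higher number from compound 1 to compound 3 (1.58 log units; beyond the scatter). Among the compounds shown here, the earlier compounds offered no pair differing in this one place, so this is the first direct sign that the methoxy, ortho to a large group, matters strongly to the number in this pair. Nothing at hand explains the size of this step.

The compounds shown leave open whether the methoxy itself is needed or whether another group in the same place, such as hydroxyl, ethoxy or chlorine, would keep the number near that of compound 1. They also leave open whether the same change would give a step of this size in a different compound pair.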